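Chloro in place of methoxymethoxy: working notes

The compounds below may be only part of what the source reports. "The series", "measured", "known", "first", "only" and "open" are said of these compounds alone.

- compound 1 `O=C1OC[C@H](Cc2ccccc2)[C@H]1Cc1ccccc1OC(F)(F)F`: 39000 nM
- compound 2 `COCOc1ccccc1C[C@H]1C(=O)OC[C@@H]1Cc1ccccc1`: 76000 nM
- compound 3 `CCCCCCCOc1ccccc1C[C@H]1C(=O)OC[C@@H]1Cc1ccccc1`: 75000 nM

All three values come from a functional assay on HL-60 cells (Homo sapiens) for cytotoxicity, read by WST assay, with a stated time of 48 h; on this read-out lower numbers stand for an effect already at smaller amounts and higher numbers for an effect only at larger amounts of compound. Compound 2, at 76000 nM, lies within the scatter of compound 1 and compound 3. The next structure is compound 4 `O=C1OC[C@H](Cc2ccccc2)[C@H]1Cc1ccccc1Cl`, and the change is chloro in place of methoxymethoxy on an aromatic carbon. The measured steps at this place are small: a 1.9-fold higher number from compound 1 to compound 2 (0.29 log units; within the scatter), a 1.9-fold higher number from compound 1 to compound 3 (0.28 log units; within the scatter) and a 1.0-fold lower number from compound 2 to compound 3 (0.01 log units; within the scatter). Within the data shown here, all of them keep the oxygen on the aromatic ring, and no measured compound carries chloro, so this support is indirect. No step beyond the scatter is expected, and the estimated step is a 1.4-fold lower number from compound 2 to compound 4 (0.14 log units; within the scatter). For compound 4 the expected value is 55000 nM, with an estimated range of 25000 nM to 110000 nM.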

Compound 4, half-maximal effective concentration: 37000 nM
Compound 4: the middle estimate sits 1.5-fold (0.17 log units) above what was measured; measured number inside the range.
By their numbers in this assay, from the lowest: compounds 4, 1, 3 and 2 (each within the scatter of the next, the first and the last beyond it).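

In this assay, among these compounds, chloro on this aromatic carbon gives the first steps at this position that lie beyond the scatter, though only modestly: a 2.1-fold lower number from compound 2 to compound 4 (0.31 log units; beyond the scatter) and a 2.0-fold lower number from compound 3 to compound 4 (0.31 log units; beyond the scatter). Against trifluoromethoxy there is no such separation, with a 1.1-fold lower number from compound 1 to compound 4 (0.02 log units; within the scatter), so in this set a value at this level does not depend on an oxygen on the aromatic ring. No measurement offered here accounts for these steps.

Open, going by these compounds, is whether an amine or a carboxylic acid at this place would shift the number further. On these data alone, whether bromo would track with chloro also remains unknown.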